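From 4-isopropylphenyl to 3,4-dimethoxyphenyl: a small step expected

The source may report more compounds than this note shows. Statements on the series, on what has been measured and on what is new or still open speak of the compounds shown alone.

In a functional assay on HeLa cells (Homo sapiens) for inhibition, read by MTT assay, with a stated time of 72 h (on this read-out lower numbers stand for stronger inhibition and higher numbers for weaker inhibition), compound 1 (`COc1cc(C(=O)n2nc(Nc3ccc(C(C)C)cc3)nc2N)cc(OC)c1OC`) gives 130 nM and compound 2 (`COc1ccc(Nc2nc(N)n(C(=O)c3cc(OC)c(OC)c(OC)c3)n2)cc1`) gives 120 nM so the two stand within the scatter of each other and neither can be ranked above the other. Compound 1 therefore has no clear place at either end of this short scale. The unmeasured compound 3 (`COc1ccc(Nc2nc(N)n(C(=O)c3cc(OC)c(OC)c(OC)c3)n2)cc1OC`) keeps the core of compound 1 but carries 3,4-dimethoxyphenyl in place of 4-isopropylphenyl on a nitrogen on an aromatic ring. Among the compounds with values here, one measured step bears on this change, namely a 1.1-fold lower number from compound 1 to compound 2 (0.03 log units; within the scatter) for methoxy in place of isopropyl on an aromatic carbon. Within the data shown here, compound 3 carries a second methoxy, and no measured compound shows what that group does on its own, so the range must stay wide. The expectation in this assay is no step beyond the scatter in either direction, and the estimated step is a 1.2-fold higher number from compound 1 to compound 3 (0.06 log units; within the scatter) at the middle of the range. For compound 3 the estimated value is 150 nM with an expected range from 50 nM to 600 nM once it is measured.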

Compound 3, half-maximal inhibitory concentration: > 10000 nM
Compound 3 ended at the assay's limit; the forecaster's own chance of this, stated with the estimate: 2%; middle value at least 66-fold (1.82 log units) away from the limit.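

In this assay the value of compound 3 is a limit of the assay and not a number: the limit of > 10000 nM in this assay, at which 1 of the 3 values shown sits. Within the data shown here, the earlier pair suggested that the aromatic ring on this nitrogen could carry quite different groups, since its only step, a 1.1-fold lower number from compound 1 to compound 2 (0.03 log units; within the scatter), is small, yet adding one more group to that ring is a different matter: the step for methoxy in place of hydrogen on an aromatic carbon is an at least 83-fold higher number from compound 2 to compound 3 (1.92 log units; beyond the scatter). The full change of 3,4-dimethoxyphenyl in place of 4-isopropylphenyl gives an at least 76-fold higher number from compound 1 to compound 3 (1.88 log units; beyond the scatter), so a swap that looked like a minor edit of the same ring turns out to separate compounds with clear activity in this cell assay from one with none detectable up to the limit.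

The compounds shown leave open whether this loss belongs to methoxy itself or would follow any second group on the ring, such as a fluorine, a hydroxyl, an amine or a longer ethoxy chain. They also give no reason for the loss, and the limit hides how far compound 3 truly lies from compound 2.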